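Methoxy for Fluoro on a Potent Nitrile Biaryl

The source may hold more compounds than are shown below. What is called first, only, known or untested is meant among the compounds shown, and "the series" means these compounds.

Within the data shown here, compound 2 `Cc1ccc2ccc(-c3cc(F)cc(C#N)c3)cc2n1` stands lowest of the two numbers so far: in a functional assay on CHO cells for inhibition of metabotropic glutamate receptor 5 (Rattus norvegicus), read by FLIPR and calcium flux (on this read-out higher numbers stand for weaker inhibition and lower numbers for stronger inhibition), compound 2 gives 0.8 nM, while compound 1 `Cc1ccc2ccc(-c3ccccc3C#N)cc2n1` gives 9800 nM in this assay, a gap far beyond the scatter. The step to compound 3 `COc1cc(C#N)cc(-c2ccc3ccc(C)nc3c2)c1` is small in structure, methoxy in place of fluoro on an aromatic carbon. Among the measured compounds shown here, no step of this kind has been measured here, so compound 3 is expected to stay close to compound 2, with a step of a 2.5-fold higher number from compound 2 to compound 3 (0.40 log units; beyond the scatter), within or barely beyond the scatter. Compound 3 is estimated at 2 nM, between 0.5 nM and 10 nM.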

Compound 3, half-maximal inhibitory concentration: 2.4 nM
Compound 3: middle estimate off by 1.2-fold (0.08 log units), on the low side, and the stated range covers the measured number.
By their numbers in this assay, from the lowest: compound 2; then compound 3; then compound 1.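

Methoxy in place of fluoro, on an aromatic carbon meta to a cyano group, gives a 3.0-fold higher number from compound 2 to compound 3 (0.48 log units; beyond the scatter) in this assay as a modest weakening. This position therefore accepts a group with more heavy atoms and a hydrogen-bond acceptor without a large loss of inhibition. Nothing available explains why the number rises on this change. The compounds shown leave open how an ethoxy group, a hydroxyl or an amine on this same carbon would read, and whether the number would keep rising with a longer chain.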